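The compounds below may be only part of what the source reports. "The series", "measured", "known", "first", "only" and "open" are said of these compounds alone.

Measured so far:
compound 1 `O=c1[nH]cnc2c1c(-c1cccs1)cn2[C@@H]1O[C@H](CO)[C@@H](O)[C@H]1O` — > 20000 nM
compound 2 `O=c1[nH]cnc2c1c(-c1cc3ccccc3o1)cn2[C@@H]1O[C@H](CO)[C@@H](O)[C@H]1O` — > 20000 nM
compound 3 `CN(C)c1ncnc2c1c(-c1cccs1)cn2[C@@H]1O[C@H](CO)[C@@H](O)[C@H]1O` — 11800 nM

In a functional assay on HL-60 cells (Homo sapiens) for antiproliferative activity, read by XTT assay, with a stated time of 72 h (a lower number here means a stronger inhibitor, a higher number a weaker inhibitor), compound 1 gives > 20000 nM, which is a limit of the assay and not a number. Compound 2 likewise gives > 20000 nM in this assay, again a limit. Among the measured compounds shown here, compound 3 gives 11800 nM in this assay, the only number among the three. How the core of compound 1 differs from the core of compound 3 is not broken down here.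

From compound 1 to compound 2 the change is 1-benzofuran-2-yl in place of thiophen-2-yl on an aromatic carbon. a step that the two limits leave unreadable from compound 1 to compound 2, a consequence of the limit of > 20000 nM in this assay, at which 2 of the 3 values shown sit.

Compound 4 `CN(C)c1ncnc2c1c(-c1cc3ccccc3o1)cn2[C@@H]1O[C@H](CO)[C@@H](O)[C@H]1O` is not yet measured. From compound 3 it carries the same change, (1-benzofuran-2-yl in place of thiophen-2-yl on an aromatic carbon). For the measured compounds named here, its one measured precedent gives no readable size, so the step expected here, a 1.2-fold lower number from compound 3 to compound 4 (0.07 log units; within the scatter), is taken as roughly neutral with wide uncertainty. For compound 4 in this assay the estimate is 10000 nM, between 3000 nM and 30000 nM.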

Compound 4, half-maximal inhibitory concentration: > 20000 nM
Compound 4: a limit, no number; the forecaster's own chance of this, stated with the estimate: 35%; middle value at least 2.0-fold (0.30 log units) away from the limit.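

In this assay, replacing thiophen-2-yl with 1-benzofuran-2-yl on the core of compound 3 gives an at least 1.6-fold higher number from compound 3 to compound 4 (0.22 log units; that floor lies within the scatter). Compound 4 gives a limit and not a number, so this shows no lower number with the change, but it does not separate the change from a neutral one. The steps on the two cores cannot be read to a size, so whether the change carries across at a similar size stays unshown: the limit of > 20000 nM in this assay, at which 3 of the 4 values shown sit.

Compound 3 is the only measured anchor, which leaves open how furan-2-yl or phenyl would read in place of thiophen-2-yl on its core. Also open, on these data alone, is whether a primary amine or a methoxy group in place of dimethylamino would give a number at all.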